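This account rests on a few compounds, and the source may have more. Where it says the series, first, only, none or still open, it means among the compounds named here.

Measured compounds:
compound 1 `CC1(C)[C@H]2CC[C@]1(C)N(Cc1cn(-c3cccc(F)c3)nn1)C(=O)C2`, 430 nM
compound 2 `CC1(C)[C@H]2CC[C@]1(C)N(Cc1cn(-c3ccccc3Br)nn1)C(=O)C2`, 140 nM
compound 3 `CC1(C)[C@H]2CC[C@]1(C)N(Cc1cn(-c3ccccc3)nn1)C(=O)C2`, 50 nM

The measurements come from a functional assay on OVCAR-3 cells (Homo sapiens) for inhibition, read by MTT assay, with a stated time of 24 h; a lower number here means a stronger inhibitor, a higher number a weaker inhibitor. Compound 1 stands at the highest number of the three: compound 2 lies a 3.1-fold lower number from compound 1 to compound 2 (0.49 log units; beyond the scatter), and compound 3 lies an 8.6-fold lower number from compound 1 to compound 3 (0.93 log units; beyond the scatter). The step from compound 2 to compound 3 is a 2.8-fold lower number from compound 2 to compound 3 (0.45 log units; beyond the scatter), so the compound bearing hydrogen at the position of the halogen gives the lowest number of the set.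

Compound 4 `Cc1ccccc1-n1cc(CN2C(=O)C[C@@H]3CC[C@@]2(C)C3(C)C)nn1` is not yet measured. It differs from compound 1 in one place: 2-methylphenyl in place of 3-fluorophenyl on an aromatic nitrogen. Going by the values given here, two measured steps bear on this change. The step of a 3.1-fold lower number from compound 1 to compound 2 (0.49 log units; beyond the scatter) shows that swapping 3-fluorophenyl for a ring carrying a group at the position of the bromo in compound 2 lowers the number modestly, while an 8.6-fold lower number from compound 1 to compound 3 (0.93 log units; beyond the scatter) shows that removing the fluoro entirely lowers it further. A 2-methylphenyl is expected to behave much like the 2-bromophenyl of compound 2, so a modest decrease is expected, a 2.9-fold lower number from compound 1 to compound 4 (0.46 log units; beyond the scatter). Compound 4 is therefore estimated at 150 nM, within a range of 60 nM to 400 nM.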

Compound 4, half-maximal inhibitory concentration: 150 nM
For compound 4 middle estimate and measured number coincide at the digits printed, within the range that was stated.
By their numbers in this assay, from the lowest: compound 3; then compounds 2 and 4 (each within the scatter of the next); then compound 1.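

In this assay, methyl and bromo are not told apart on this phenyl ring, with a 1.1-fold higher number from compound 2 to compound 4 (0.03 log units; within the scatter) between the 2-bromophenyl and the 2-methylphenyl. The cost of a group over plain phenyl is therefore no longer seen with a halogen alone: methyl in place of hydrogen gives a 3.0-fold higher number from compound 3 to compound 4 (0.48 log units; beyond the scatter), and the 2-methylphenyl still keeps a 2.9-fold lower number from compound 1 to compound 4 (0.46 log units; beyond the scatter) relative to the 3-fluorophenyl, so compounds 2 and 4 both lie between compounds 3 and 1. No measurement shown here accounts for these differences.

What the compounds leave open is whether a methoxy, an amine or a carboxylic acid in place of the methyl would fall with compounds 2 and 4. They also leave open whether the high number of compound 1 follows from the fluoro itself or from where it stands on the ring.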